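The compounds below may be only part of what the source reports. "The series", "measured", "known", "first", "only" and "open" are said of these compounds alone.

Measured in an in vitro ADME assay on microsomes from liver (Homo sapiens) for pharmacokinetics, read by LC-MS, with a stated time of 10 min, tested at 1 uM; on this read-out higher numbers stand for fast clearance and lower numbers for slow clearance:
- compound 1 `Cc1ccc(NC(=O)[C@H]2CN(C)C[C@@H]2c2ccc(/C=C/C(=O)Nc3ccccc3N)cc2)cc1`: 15 mL/min/kg
- compound 2 `CN1C[C@H](C(=O)Nc2ccccn2)[C@@H](c2ccc(/C=C/C(=O)Nc3ccccc3N)cc2)C1`: 8 mL/min/kg

Compound 2 has the lower of these two numbers, yet compound 2 and compound 1 lie within the scatter of each other. Compound 3 `CN1C[C@H](C(=O)Nc2ccc(Cl)cn2)[C@@H](c2ccc(/C=C/C(=O)Nc3ccccc3N)cc2)C1` differs from compound 2 by chloro in place of hydrogen on an aromatic carbon, which turns pyridin-2-yl into 5-chloropyridin-2-yl. Among the compounds with values here, the only measured step, a 1.9-fold lower number from compound 1 to compound 2 (0.27 log units; within the scatter), concerns the same group but is a different change, so it is a weak guide. No shift beyond the scatter is expected in this assay, and the expected step is a 1.3-fold higher number from compound 2 to compound 3 (0.10 log units; within the scatter). For compound 3 the estimated clearance is 10 mL/min/kg, with an expected range of 5 mL/min/kg to 20 mL/min/kg.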

Compound 3, clearance: 13 mL/min/kg
Beside the measured number, compound 3's estimate is 1.3-fold (0.11 log units) below it, within the range that was stated.
By their numbers in this assay, from the lowest: compounds 2, 3 and 1 (each within the scatter of the next).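

In this assay, chloro on the aromatic carbon two atoms from the ring nitrogen gives a 1.6-fold higher number from compound 2 to compound 3 (0.21 log units; within the scatter), so this position accepts chloro with no shift beyond the scatter. Replacing 4-methylphenyl with 5-chloropyridin-2-yl on the amide-type nitrogen gives a 1.2-fold lower number from compound 1 to compound 3 (0.06 log units; within the scatter), which places compound 1, compound 2 and compound 3 within the scatter of one another. No evidence on the origin of these steps is available. On these data alone, it remains open whether an amine, a methoxy group or a carboxylic acid on this carbon would move clearance beyond the scatter.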